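Replacing 2,6-dichlorophenyl with 2,4,6-trifluorophenyl on a shared core

The source may hold more compounds than are shown below. What is called first, only, known or untested is meant among the compounds shown, and "the series" means these compounds.

Measured so far in an ADME assay on MT4 cells (Homo sapiens) for inhibition, read by MTT assay, with a stated time of 5 days (on this read-out lower numbers stand for higher toxicity in this test and higher numbers for lower toxicity in this test), for two compounds:
Compound 1 `Cc1cccc(C)c1Oc1cc(Nc2ccc(C#N)cc2)ncc1[N+](=O)[O-]` gives 126000 nM
Compound 2 `N#Cc1ccc(Nc2cc(Oc3c(Cl)cccc3Cl)c([N+](=O)[O-])cn2)cc1` gives 27700 nM

Compound 2 holds the lower of the two numbers. Compound 3 `N#Cc1ccc(Nc2cc(Oc3c(F)cc(F)cc3F)c([N+](=O)[O-])cn2)cc1` has not yet been measured. It differs from compound 2 by 2,4,6-trifluorophenyl in place of 2,6-dichlorophenyl on an oxygen on an aromatic ring. Within the data shown here, the one measured step at this place is a 4.5-fold lower number from compound 1 to compound 2 (0.66 log units; beyond the scatter) with 2,6-dichlorophenyl in place of 2,6-dimethylphenyl. Among the measured compounds shown here, no measured compound carries 2,4,6-trifluorophenyl, so that step is only a rough guide. A smaller step is expected in this assay leaning toward a higher number, and it may not exceed the scatter. The expected change is a 1.4-fold higher number from compound 2 to compound 3 (0.16 log units; within the scatter) in all. Compound 3 is estimated at 40000 nM with an expected range from 12000 nM to 130000 nM for now.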

Compound 3, half-maximal cytotoxic concentration: 3540 nM
For compound 3 the middle estimate is 11-fold (1.05 log units) above the measured one; measured number below the stated range.
By their numbers in this assay, from the lowest: compound 3; then compound 2; then compound 1.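

In this assay the group on the oxygen can move the number further than the earlier pair showed: a 7.8-fold lower number from compound 2 to compound 3 (0.89 log units; beyond the scatter) comes with 2,4,6-trifluorophenyl in place of 2,6-dichlorophenyl, and a 36-fold lower number from compound 1 to compound 3 (1.55 log units; beyond the scatter) comes with the same group in place of 2,6-dimethylphenyl. Both steps lie beyond the scatter, so compound 3 shows the highest toxicity in this test of the three, and the numbers fall from 2,6-dimethylphenyl through 2,6-dichlorophenyl to 2,4,6-trifluorophenyl. No measurement at hand bears on the reason for this order.

The compounds shown leave open whether the lower number needs all three fluorine atoms or would persist with fewer of them. They also leave open how an unsubstituted phenyl ring or an amine on this ring would read, and whether the same order holds on any other core.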